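The compounds below may be only part of what the source reports. "The series", "measured", "known", "first", "only" and "open" are said of these compounds alone.

Working notes on the series. Among the measured compounds shown here, compound 3 `COC(=O)[C@@]1(C)CCC=C2[C@@H]1CC[C@@H](C)[C@]2(C)Cc1c(C)[nH]c2c(Br)cccc12` stands at the highest number of the three measured so far in a functional assay on A549 cells (Homo sapiens) for inhibition, read by sulforhodamine B assay, with a stated time of 48 h (a higher number here means a weaker inhibitor of growth, a lower number a stronger inhibitor of growth), with compound 3 giving 27000 nM; compound 1 `COC(=O)[C@@]1(C)CCC=C2[C@@H]1CC[C@@H](C)[C@]2(C)Cc1c[nH]c2c(Cl)cccc12` gives 22000 nM and compound 2 `COC(=O)[C@@]1(C)CCC=C2[C@@H]1CC[C@@H](C)[C@]2(C)Cc1c(C)[nH]c2c(C)cccc12` gives 14000 nM, both within the scatter of compound 3, so no order among the three can be read from the numbers.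

Compound 4 `COC(=O)[C@@]1(C)CCC=C2[C@@H]1CC[C@@H](C)[C@]2(C)Cc1c(C)[nH]c2c(Cl)cccc12` differs from compound 3 by chloro in place of bromo on an aromatic carbon. For the measured compounds named here, one measured step bears on this: the swap of a halogen for a methyl at the same aromatic carbon gave a 1.9-fold higher number from compound 2 to compound 3 (0.29 log units; within the scatter), a move that stays within the scatter. Going by the values given here, the only other pair with chloro at that carbon, compound 1 against compound 3, differs in two places and is not a clean comparison; its two values lie within the scatter of each other.

Among the compounds with values here, nothing among the measured compounds shows a halogen exchange at this carbon moving the number beyond the scatter. Compound 4 is therefore expected to sit close to compound 3, with a 1.2-fold lower number from compound 3 to compound 4 (0.09 log units; within the scatter) as the estimated step and no shift beyond the scatter expected. The estimate for compound 4 in this assay is 22000 nM, within a range of 11000 nM to 44000 nM.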

Compound 4, concentration for 50% growth inhibition: 20000 nM
Compound 4: middle estimate off by 1.1-fold (0.04 log units), on the high side; measured number inside the range.
By their numbers in this assay, from the lowest: compounds 2, 4, 1 and 3 (each within the scatter of the next).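

The halogen exchange on this aromatic carbon, ortho to a fused ring and meta to a fused ring, now has a direct reading in this assay: chloro in place of bromo gives a 1.4-fold lower number from compound 3 to compound 4 (0.13 log units; within the scatter), and chloro in place of methyl gives a 1.4-fold higher number from compound 2 to compound 4 (0.15 log units; within the scatter), so methyl, chloro and bromo at this carbon cannot be told apart by their numbers. Compound 4 also supplies the one-place link that compound 1 and compound 3 lacked, and methyl in place of hydrogen on a different aromatic carbon of the shared core gives a 1.1-fold lower number from compound 1 to compound 4 (0.04 log units; within the scatter), so this second place likewise shows no move beyond the scatter. No measurement at hand offers an explanation for these small steps.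

The compounds shown carry only methyl, chloro and bromo at the first carbon, so whether an amine or a carboxylic acid there would move the number beyond the scatter remains open. From the compounds shown here alone, all four also share the same methyl ester on the core, and what a longer chain in its place would do in this assay is equally open.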